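This account rests on a few compounds, and the source may have more. Where it says the series, first, only, none or still open, it means among the compounds named here.

Compound 1 `CC(C)N(Cc1cccc(OCCCCCC(=O)O)c1)C(=O)c1ccc(-c2cccc3ccccc23)cc1` in an ADME assay on Raji cells (Homo sapiens) for cytotoxicity, read by CellTiter-Glo and resazurin assay, with a stated time of 72 h (on this read-out higher numbers stand for an effect only at larger amounts of compound and lower numbers for an effect already at smaller amounts), gives > 26000 nM, which is a limit of the assay and not a number.
Compound 2 `CC(C)N(Cc1cccc(OCCCCCC(=O)O)c1)C(=O)c1ccc(-c2ccncc2)cc1` in this assay gives > 26000 nM, again a limit of the assay.
Compound 3 `CC(C)N(Cc1cccc(OCCCCCC(=O)O)c1)C(=O)c1ccc(-c2cccc(O)c2)cc1` in this assay gives > 26000 nM, also a limit of the assay.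

All three measured compounds share one core and differ only in the group on the outer aromatic ring. Because every value sits at the limit of > 26000 nM in this assay, at which 3 of the 3 values shown sit, none of the three can be placed in order: the step from compound 1 to compound 2 is a step that the two limits leave unreadable from compound 1 to compound 2, the step from compound 1 to compound 3 is a step that the two limits leave unreadable from compound 1 to compound 3, and the step from compound 2 to compound 3 is a step that the two limits leave unreadable from compound 2 to compound 3. Compound 3 therefore stands only as a limit, with nothing to set it apart from compound 1 or compound 2.

Compound 4 `CC(C)N(Cc1cccc(OCCCCCC(=O)O)c1)C(=O)c1ccc(-c2c[nH]c3ccccc23)cc1` is the unmeasured compound; it differs from compound 3 by 1H-indol-3-yl in place of 3-hydroxyphenyl on an aromatic carbon. Since the three steps already measured at this position all stayed at the limit, no readable step is expected in this assay, in either direction. The estimated step from compound 3 to compound 4 is a number no higher from compound 3 to compound 4 (the limit leaves the size open), and compound 4 is expected to give about 26000 nM, with a range from 9000 nM to 60000 nM, most likely again reported only as a limit.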

Compound 4, half-maximal effective concentration: > 26000 nM
Compound 4 ended at the assay's limit; the forecaster's own chance of this, stated with the estimate: 80%; the middle value sits exactly at the limit.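

Compound 4 also ends at the limit, so the steps to it from compound 1, compound 2 and compound 3 cannot be read, and the four compounds cannot be put in order: the limit of > 26000 nM in this assay, at which 4 of the 4 values shown sit. The compounds shown leave open whether any group in this place could give a readable number in this assay.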